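The source may hold more compounds than are shown below. What is called first, only, known or untested is meant among the compounds shown, and "the series" means these compounds.

The measured compounds:
compound 1, `N#C/C(=C\c1c[nH]c2cc(F)ccc12)C(=O)c1c[nH]c2cc(F)ccc12`, with > 50000 nM in a functional assay on PC-3 cells (Homo sapiens) for cytotoxicity, read by WST assay, with a stated time of 24 h (on this read-out lower numbers stand for stronger inhibition and higher numbers for weaker inhibition), a limit of the assay
compound 2, `COc1ccc2[nH]cc(/C=C(\C#N)C(=O)c3c[nH]c4cc(F)ccc34)c2c1`, with > 50000 nM in this assay, a limit of the assay
compound 3, `COc1ccc2c(C(=O)/C(C#N)=C/c3c[nH]c4cc(F)ccc34)c[nH]c2c1`, with 36000 nM in this assay

Compound 1 carries only fluoro substituents on the shared core, and in this assay compound 1 reaches only > 50000 nM, which is a limit of the assay and not a number. Compound 3 differs from it in one place: methoxy in place of fluoro on an aromatic carbon. In this assay compound 3 gives 36000 nM. The step is an at least 1.3-fold lower number from compound 1 to compound 3 (0.14 log units; that floor lies within the scatter), and its size is known only as a floor because of the limit of > 50000 nM in this assay, at which 2 of the 3 values shown sit.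

How the core of compound 2 differs from that of compound 1 is not broken down here. In this assay compound 2 also reaches only > 50000 nM, again a limit of the assay.

Compound 4, `COc1ccc2c(C(=O)/C(C#N)=C/c3c[nH]c4ccc(OC)cc34)c[nH]c2c1`, is compound 2 with the same change made once more: methoxy in place of fluoro on an aromatic carbon. Its value in this assay is not yet known. Resting on an at least 1.3-fold lower number from compound 1 to compound 3 (0.14 log units; that floor lies within the scatter), which is the one measured instance of this change, the step to compound 4 is expected to be an at least 1.1-fold lower number from compound 2 to compound 4 (0.04 log units; that floor lies within the scatter). Compound 4 is therefore estimated at 45000 nM, most likely between 15000 nM and 150000 nM, with a real chance that the assay again reports only a limit.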

Compound 4, half-maximal inhibitory concentration: 31100 nM
Compound 4: the middle estimate sits 1.4-fold (0.16 log units) above what was measured, within the range that was stated.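

On the second core, the change of methoxy in place of fluoro gives in this assay an at least 1.6-fold lower number from compound 2 to compound 4 (0.20 log units; that floor lies within the scatter). Set beside the first instance, both steps point the same way, but both are known only as floors within the scatter, so the data do not establish a real gain on either core and cannot say whether the change is worth the same on both: the same change on two cores in this assay, an at least 1.3-fold lower number (0.14 log units; that floor lies within the scatter) from compound 1 to compound 3 and an at least 1.6-fold lower number (0.20 log units; that floor lies within the scatter) from compound 2 to compound 4; the limit leaves it open whether they differ In both pairs the fluoro partner, compound 1 and compound 2, sits at a limit of the assay and not at a number, and the true size of each step stays unknown because of that limit: the limit of > 50000 nM in this assay, at which 2 of the 4 values shown sit.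

The compounds shown leave open how groups other than fluoro and methoxy would read at these places on the shared core, for example an amine, a hydroxyl or a longer alkoxy chain. They also leave open what a carboxylic acid in place of the nitrile would give, and where the true values of compound 1 and compound 2 lie.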